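Sulfonyl aryl swap on the shared core, compound 3

This account rests on a few compounds, and the source may have more. Where it says the series, first, only, none or still open, it means among the compounds named here.

Measured so far:
compound 1 `CC(C)n1nc(S(=O)(=O)c2cccc3ccccc23)c2cc(N3CCN(C)CC3)ccc21` — 1.8 nM
compound 2 `Cc1ccc(S(=O)(=O)c2n[nH]c3ccc(N4CCN(C)CC4)cc23)cc1` — 112 nM

In a functional assay on HeLa cells for antagonist activity at 5-hydroxytryptamine receptor 6 (Homo sapiens) (a higher number here means a weaker inhibitor, a lower number a stronger inhibitor), compound 2 gives 112 nM, the higher of the two numbers recorded; compound 1 gives 1.8 nM, a lower number by a margin beyond the scatter. Among the measured compounds shown here, the two structures differ in more than one place, so no single step between them is counted.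

Compound 3 `CN1CCN(c2ccc3[nH]nc(S(=O)(=O)c4ccccc4Cl)c3c2)CC1` is not yet measured. It differs from compound 2 in one place only: 2-chlorophenyl in place of 4-methylphenyl on a sulfonyl sulfur. The sulfonyl link, the basic ring on the shared core and the ring hydrogen are unchanged.

For the measured compounds named here, nothing isolates the aryl group on the sulfonyl sulfur, so no measured step supports a direction. The expectation is a step from compound 2 to compound 3 of a 1.1-fold lower number from compound 2 to compound 3 (0.05 log units; within the scatter), with a small change in either direction not excluded. Compound 3 is estimated at 100 nM in this assay, within a range from 30 nM to 400 nM.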

Compound 3, half-maximal inhibitory concentration: 101 nM
Compound 3: middle estimate off by 1.0-fold (0.00 log units), on the low side; measured number inside the range.
By their numbers in this assay, from the lowest: compound 1; then compounds 3 and 2 (each within the scatter of the next).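

In this assay, among the compounds shown here, this is the first step that isolates the aryl group on the sulfonyl sulfur: 2-chlorophenyl in place of 4-methylphenyl gives a 1.1-fold lower number from compound 2 to compound 3 (0.04 log units; within the scatter) with the sulfonyl link, the basic ring and the ring hydrogen held fixed. At this position, then, the two aryl groups cannot be told apart in this measurement, even though the chlorine and the methyl group are carried at different places on the ring. No measured evidence on the origin of this result is available.

As far as these compounds go, whether a pyridine ring in place of the phenyl ring, or an amine or a carboxylic acid on it, would move the number remains open. For the compounds shown here, no single step reaches compound 1, so the separate contributions of its naphthyl and isopropyl groups also remain open.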